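The source may report more compounds than this note shows. Statements on the series, on what has been measured and on what is new or still open speak of the compounds shown alone.

In a functional assay on HepG2 cells (Homo sapiens) for antiproliferative activity, read by MTT assay, with a stated time of 48 h (on this read-out lower numbers stand for stronger inhibition and higher numbers for weaker inhibition), compound 1 (`CC(=O)N1N=C(c2ccc3ccccc3c2)OC1c1cccc(Br)c1`) gives 1.68 ug/mL, compound 2 (`CC(=O)N1N=C(c2ccc3ccccc3c2)OC1c1ccccc1F`) gives 3.36 ug/mL, and compound 3 (`CC(=O)N1N=C(c2ccc3ccccc3c2)OC1c1ccccc1[N+](=O)[O-]`) gives 12.3 ug/mL, the highest of the three numbers and so the weakest inhibition. Compound 4 (`CC(=O)N1N=C(c2ccc3ccccc3c2)OC1c1ccc([N+](=O)[O-])cc1`) has 4-nitrophenyl in place of 2-nitrophenyl on a saturated ring carbon. Among the compounds with values here, no measured pair makes this exact change, so the evidence is indirect. Changing this aryl group gave a 2.0-fold higher number from compound 1 to compound 2 (0.30 log units; within the scatter), a 3.7-fold higher number from compound 2 to compound 3 (0.56 log units; beyond the scatter) and a 7.3-fold higher number from compound 1 to compound 3 (0.86 log units; beyond the scatter). A modest shift towards a lower number, or none beyond the scatter, therefore seems likely. The expected change is a 1.8-fold lower number from compound 3 to compound 4 (0.24 log units; within the scatter). For compound 4 the estimated value is 7 ug/mL, with an expected range from 2.5 ug/mL to 18 ug/mL.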

Compound 4, half-maximal inhibitory concentration: 8.1 ug/mL
For compound 4 the middle estimate is 1.2-fold (0.06 log units) below the measured one; the measured number falls inside the stated range.
By their numbers in this assay, from the lowest: compounds 1 and 2 (each within the scatter of the next); then compounds 4 and 3 (each within the scatter of the next).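

Swapping 2-nitrophenyl for 4-nitrophenyl in this assay gives a 1.5-fold lower number from compound 3 to compound 4 (0.18 log units; within the scatter), so moving the nitro group around the phenyl ring makes no clear difference between these two compounds. The 4-nitrophenyl group still differs clearly from the other two aryl groups, with a 2.4-fold higher number from compound 2 to compound 4 (0.38 log units; beyond the scatter) and a 4.8-fold higher number from compound 1 to compound 4 (0.68 log units; beyond the scatter), so both nitrophenyl compounds give higher numbers than the 3-bromophenyl and 2-fluorophenyl compounds. No supporting data are available to explain these results. Still open, as far as these compounds go, is how a phenyl carrying an amine or a carboxylic acid would compare at this position.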